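The compounds below may be only part of what the source reports. "The series", "measured", "known", "first", "only" and "open" are said of these compounds alone.

Of the compounds shown here, three of the shared core have been measured. Compound 1 `Nc1nc2c(c(-c3ccccc3)cn2[C@@H]2O[C@H](CO)[C@@H](O)[C@H]2O)c(=O)[nH]1` gives in a functional assay on CCRF-CEM cells (Homo sapiens), read by MTT assay, with a stated time of 72 h (a higher number here means a weaker inhibitor, a lower number a stronger inhibitor), a value of > 100000 nM, which is a limit of the assay and not a number. Compound 2 `CN(C)c1ncnc2c1c(-c1cc3ccccc3o1)cn2[C@@H]1O[C@H](CO)[C@@H](O)[C@H]1O` gives in this assay > 20000 nM, again a limit rather than a number. Compound 3 `Cc1ncnc2c1c(-c1cc3ccccc3o1)cn2[C@@H]1O[C@H](CO)[C@@H](O)[C@H]1O` differs from compound 2 only by a methyl in place of dimethylamino on an aromatic carbon, and in this assay compound 3 gives 17300 nM. The step of an at least 1.1-fold lower number from compound 2 to compound 3 (0.06 log units; that floor lies within the scatter) is thus not resolved beyond the scatter. Compound 2 therefore stands only at a limit, (the limit of > 20000 nM in this assay, at which 1 of the 3 values shown sits), and compound 1 sits at a further limit, (the limit of > 100000 nM in this assay, at which 1 of the 3 values shown sits).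

Compound 4 `CN(C)c1ncnc2c1c(-c1ccoc1)cn2[C@@H]1O[C@H](CO)[C@@H](O)[C@H]1O` changes the aryl group instead: furan-3-yl in place of 1-benzofuran-2-yl on an aromatic carbon. For the measured compounds named here, no measured step between compound 1, compound 2 and compound 3 touches this position, so none bears directly on the change; the only guide is that compound 2 itself reaches no number. Compound 4 is therefore expected to stay near that limit, with a step that the limit leaves unreadable from compound 2 to compound 4 expected to be no change beyond the scatter. The estimate for compound 4 is 50000 nM, in a range from 15000 nM to 200000 nM.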

Compound 4, half-maximal inhibitory concentration: 13300 nM
Beside the measured number, compound 4's estimate is 3.8-fold (0.58 log units) above it; measured number outside the range, below it.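

Replacing 1-benzofuran-2-yl with furan-3-yl on this aromatic carbon gives an at least 1.5-fold lower number from compound 2 to compound 4 (0.17 log units; that floor lies within the scatter). In this assay compound 4 gives 13300 nM, a number and not a limit, so with dimethylamino on the core, the six-membered aromatic ring of carbon only in 1-benzofuran-2-yl is not needed for a measurable reading. The true size of the step cannot be read because compound 2 stands only at a limit: the limit of > 20000 nM in this assay, at which 1 of the 4 values shown sits.

The compounds shown leave open whether a thiophene ring, or a short chain ending in an amine, on this aromatic carbon would bring the number lower. Also open, as far as these compounds go, is how furan-3-yl reads with methyl in place of dimethylamino, the pairing that would set it directly against compound 3.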